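The source may hold more compounds than are shown below. What is called first, only, known or untested is meant among the compounds shown, and "the series" means these compounds.

Measured compounds:
Compound 1, `CC(C)CC1n2cncc2CN(Cc2ccc(OC(F)(F)F)cc2)S1(=O)=O`, gives 13% in an assay on isolated protein for inhibition of Aromatase (Homo sapiens), tested at 1 uM; on this read-out lower numbers stand for less inhibition and higher numbers for more inhibition at the one concentration tested (going by the name of the read-out).
Compound 2, `C[C@@H](c1ccc(Cl)cc1)N1Cc2cncn2C(C[C@@H](O)c2ccccc2)S1(=O)=O`, gives 6% in this assay.
Compound 3, `CC(C)CC1n2cncc2CN([C@H](C)c2ccc(Cl)cc2)S1(=O)=O`, gives 24% in this assay.

Among these three numbers compound 3 stands highest in this assay. Its nearest neighbour is compound 1, whose number lies lower by a gap that is beyond the usual scatter, and compound 2 lies furthest, also beyond the scatter. Among the compounds with values here, no two of the measured compounds differ in only one place, so no single step between them can be read off, and the gaps say only that compound 3 sits above the other two.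

Compound 4, `CC(C)CC1n2cncc2CN([C@@H](C)c2ccc(Cl)cc2)S1(=O)=O`, has not yet been measured. It differs from compound 3 as follows: the two compounds have the same atoms and bonds; at least one stereo element is drawn with a configuration in one of them and without one in the other: 1 of 2 stereo elements differ; a stereocentre at a saturated chain carbon is drawn R in compound 3 and S in compound 4. Nothing enters and nothing leaves; only the drawn configuration at one stereocentre on a saturated chain carbon changes.

Within the data shown here, there is no measured pair in this set that shows what such a change of configuration does in this assay. Such changes can leave the number where it is or move it in either direction, and since compound 3 already sits at a modest level, a drop is somewhat more likely than a rise. Compound 4 is expected to give 15% in this assay, with a range from 2% to 38%. The expected step of a number 9 percentage points lower from compound 3 to compound 4 (within the scatter) is a moderate fall, though a value within the scatter of compound 3 remains well possible.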

Compound 4, a percentage reported as inhibition, at one concentration (the size of the read-out at that concentration, not a potency): 56%
Beside the measured number, compound 4's estimate is 41 percentage points below it; measured number outside the range, above it.
By their numbers in this assay, from the lowest: compounds 2 and 1 (each within the scatter of the next); then compound 3; then compound 4.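

In this assay the spatial arrangement at this saturated chain carbon matters on its own: with the same atoms and bonds, switching the drawn configuration from R to S gives a number 32 percentage points higher from compound 3 to compound 4 (beyond the scatter). A second place on the shared core also moves the number, as isopropyl in place of hydroxy(phenyl)methyl on a saturated chain carbon bound to a saturated ring carbon gives a number 50 percentage points higher from compound 2 to compound 4 (beyond the scatter), so the result of changing one place can be large at either site, though each rests on a single pair. The first step should be read with care, as it depends on how the two structures are drawn: the fact that one of compounds 3 and 4 is drawn with a defined configuration and the other without, at the place where they differ.

The compounds shown leave open how the second stereo element affects the number, as it does not differ between compound 3 and compound 4. They also leave open whether the S preference holds with a longer chain, such as ethyl, in place of the methyl on this stereocentre, or with an amine in place of the chlorine on the phenyl ring.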